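The source may hold more compounds than are shown below. What is called first, only, known or untested is meant among the compounds shown, and "the series" means these compounds.

For the measured compounds named here, in an ADME assay on L6 cells (Rattus norvegicus) for cytotoxicity (a higher number here means a weaker inhibitor, a lower number a stronger inhibitor), three compounds built on one shared core have numbers so far. Compound 1 `Cc1nc(-c2ccccn2)nc(N)c1Cl` gives 85300 nM, compound 2 `Cc1nc(-c2ccccn2)nc(NCc2ccccc2)c1Cl` gives 70100 nM and compound 3 `Cc1nc(-c2ccccn2)nc(NCCCc2ccccc2)c1Cl` gives 73500 nM. These three values lie within the usual scatter of repeated measurements, so compound 3 cannot be told apart from the other two.

The next compound is compound 4 `Cc1nc(-c2ccccn2)nc(NCC2CCCCC2)c1Cl`, which differs from compound 3 in one place: cyclohexyl in place of phenethyl on a saturated chain carbon bound to a nitrogen on an aromatic ring. In words, cyclohexyl stands in place of phenethyl on a saturated chain carbon bound to a nitrogen on an aromatic ring.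

Going by the values given here, two measured steps bear on this change, since both altered the group at that same part of the molecule. Benzyl in place of hydrogen gave a 1.2-fold lower number from compound 1 to compound 2 (0.09 log units; within the scatter), and phenethyl in place of phenyl gave a 1.0-fold higher number from compound 2 to compound 3 (0.02 log units; within the scatter). Both steps are small and stay within the scatter. Among the compounds with values here, no measured compound yet carries a non-aromatic ring in this place, so the data offer only indirect guidance and the range must stay wide.

The expected change in this assay is therefore none beyond the scatter, an estimated 1.1-fold lower number from compound 3 to compound 4 (0.05 log units; within the scatter). The expected value for compound 4 is 65000 nM, within an estimated range of 30000 nM to 110000 nM.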

Compound 4, half-maximal inhibitory concentration: 42400 nM
The estimate for compound 4 lay 1.5-fold (0.19 log units) above the measured number, and the stated range covers the measured number.
By their numbers in this assay, from the lowest: compounds 4, 2, 3 and 1 (each within the scatter of the next).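

For the compounds shown here, compound 4 is the first here with a non-aromatic ring at this place, on a saturated chain carbon bound to a nitrogen on an aromatic ring. In this assay, cyclohexyl gives a 1.7-fold lower number from compound 3 to compound 4 (0.24 log units; within the scatter) when it replaces phenethyl and a 1.7-fold lower number from compound 2 to compound 4 (0.22 log units; within the scatter) when it replaces phenyl, so exchanging the aromatic ring for a non-aromatic one of the same size produces no change that can be told from the scatter. Even the whole cyclohexylmethyl group in place of hydrogen on the nitrogen gives a 2.0-fold lower number from compound 1 to compound 4 (0.30 log units; within the scatter), which leaves all four compounds unresolved from one another in this assay, and nothing measured here offers an explanation for the small differences.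

The compounds shown leave open whether any group at this place can move the number beyond the scatter, as each one carries only hydrogen or a carbon-only ring group there. On these data alone, a carboxylic acid, a piperidine or a longer alkyl chain would test that question, and the other parts of the shared core remain unexplored in these compounds.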